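Chloro in place of methoxy on compound 1

The source may hold more compounds than are shown below. What is called first, only, known or untested is meant among the compounds shown, and "the series" means these compounds.

Among the compounds with values here, in a functional assay on HCT-116 cells (Homo sapiens) for inhibition, read by MTT assay, with a stated time of 48 h (on this read-out lower numbers stand for stronger inhibition and higher numbers for weaker inhibition), compound 1 (`C/C=C/C(=O)N(Cc1ccc(OC)c(OC)c1)c1cc(OC)c(OC)c(OC)c1`) gives 32800 nM and holds the higher of the two numbers so far. Compound 2 (`C#CC(=O)N(Cc1ccc(OC)c(O)c1)c1cc(OC)c(OC)c(OC)c1`) gives 310 nM there, lower by more than the scatter, but it differs from compound 1 in more than one place and offers no single-change guide. Compound 3 (`C/C=C/C(=O)N(Cc1ccc(OC)c(Cl)c1)c1cc(OC)c(OC)c(OC)c1`) is otherwise the same as compound 1 but carries chloro in place of methoxy on an aromatic carbon, ortho to a methoxy group (chloro in place of methoxy on an aromatic carbon) on the shared core. In this assay a modest move toward a lower number is expected, an estimated step (a 2.3-fold lower number from compound 1 to compound 3 (0.37 log units; beyond the scatter)) that may stay close to the scatter. For compound 3 the estimated value is 14000 nM with a range from 4000 nM to 40000 nM in this read-out.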

Compound 3, half-maximal inhibitory concentration: 1420 nM
Compound 3: middle estimate off by 9.9-fold (0.99 log units), on the high side; measured number outside the range, below it.
By their numbers in this assay, from the lowest: compound 2; then compound 3; then compound 1.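

In this assay, within the data shown here, this is the first single-change reading on the shared core, and the change from methoxy to chloro, ortho to a methoxy group, gives a 23-fold lower number from compound 1 to compound 3 (1.36 log units; beyond the scatter) as a large step. The number at this position therefore depends strongly on the group it carries, and methoxy is not needed there for the lower value. No measurement at hand accounts for the size of this step. The compounds shown leave open how bromo or a nitrile would read on this aromatic carbon. They also leave open whether chloro gives a step of like size on the core of compound 2.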